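Sulfide for Sulfone in a Cyano-Bearing Anilide

The compounds below may be only part of what the source reports. "The series", "measured", "known", "first", "only" and "open" are said of these compounds alone.

compound 1: `CC(O)(C(=O)Nc1cccc(S(=O)(=O)c2ccccc2)c1)C(F)(F)F`; in a functional assay (Cavia porcellus) with sulfonylurea receptors; K-ATP channels (Homo sapiens) as the target (on this read-out higher numbers stand for weaker inhibition and lower numbers for stronger inhibition), compound 1 reaches only a limit, > 30000 nM
compound 2: `CC(O)(C(=O)Nc1ccc(C#N)c(S(=O)(=O)c2ccccc2)c1)C(F)(F)F`; in this assay compound 2 gives 2600 nM

For the measured compounds named here, compound 2 holds the only number among the two values shown; the other value is a limit, (the limit of > 30000 nM in this assay, at which 1 of the 2 values shown sits). Going by the values given here, the single measured step, an at least 11-fold lower number from compound 1 to compound 2 (1.06 log units; beyond the scatter), is large and beyond the scatter. Compound 3, `CC(O)(C(=O)Nc1ccc(C#N)c(Sc2ccccc2)c1)C(F)(F)F`, differs from compound 2 by phenylsulfanyl in place of phenylsulfonyl on an aromatic carbon. No measured step touches this change: the one measured step concerns the cyano group, which compound 3 keeps, so nothing in the shown data sets the direction or size of the sulfone-to-sulfide move. Compound 3 is therefore expected to stay near compound 2, with a wide range to allow either direction, and a step of a 1.5-fold higher number from compound 2 to compound 3 (0.19 log units; within the scatter) is estimated. Compound 3 is expected to give about 4000 nM, with a range from 1000 nM to 20000 nM.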

Compound 3, half-maximal inhibitory concentration: 8300 nM
Estimate against measurement, compound 3: 2.1-fold (0.32 log units) below; the measured number falls inside the stated range.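

Replacing phenylsulfonyl with phenylsulfanyl gives a 3.2-fold higher number from compound 2 to compound 3 (0.50 log units; beyond the scatter) in this assay and so weakens inhibition, which shows that this aromatic carbon, ortho to a cyano group, responds to the change. Up to now the only measured step was an at least 11-fold lower number from compound 1 to compound 2 (1.06 log units; beyond the scatter) for the cyano group, so this is the first reading on the phenylsulfonyl group itself. The phenylsulfonyl compound keeps the lower number, yet compound 3 still gives 8300 nM in this assay as a number and not a limit.

The compounds shown leave open whether the same step would hold without the cyano group, and how a phenylsulfinyl, phenoxy or phenylamino group would read at this place. No measurement shown accounts for the step.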